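Swapping the indole for a dimethylaminophenyl group

This account rests on a few compounds, and the source may have more. Where it says the series, first, only, none or still open, it means among the compounds named here.

Measured compounds:
compound 1 `COc1cc(-c2ccnc3cc(-c4ccc(F)cc4)nn23)cc(OC)c1OC`: 5030 nM
compound 2 `COc1cc(-c2ccnc3cc(-c4c[nH]c5ccccc45)nn23)cc(OC)c1OC`: 35 nM
compound 3 `COc1cc(-c2ccnc3cc(-c4cn(C)c5ccccc45)nn23)cc(OC)c1OC`: 762 nM

In a functional assay on HCT-116 cells (Homo sapiens) for inhibition, read by CCK-8 assay, with a stated time of 48 h (on this read-out higher numbers stand for weaker inhibition and lower numbers for stronger inhibition), compound 2 gives the lowest number of the three, with compound 3 nearest and compound 1 furthest away. Compound 4 `COc1cc(-c2ccnc3cc(-c4ccc(N(C)C)cc4)nn23)cc(OC)c1OC` differs from compound 2 in one place: 4-(dimethylamino)phenyl in place of 1H-indol-3-yl on an aromatic carbon. Going by the values given here, two measured steps bear on this change. Replacing the 4-fluorophenyl of compound 1 by 1H-indol-3-yl gave a 140-fold lower number from compound 1 to compound 2 (2.16 log units; beyond the scatter), and capping the indole nitrogen with methyl gave a 22-fold higher number from compound 2 to compound 3 (1.34 log units; beyond the scatter). Compound 4 carries a six-membered ring with no hydrogen-bond donor, so a large step to a higher number is expected, a 43-fold higher number from compound 2 to compound 4 (1.63 log units; beyond the scatter). Compound 4 is therefore estimated at 1500 nM, within 300 nM to 6000 nM.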

Compound 4, half-maximal inhibitory concentration: 2050 nM
For compound 4 the middle estimate is 1.4-fold (0.14 log units) below the measured one; the measured number falls inside the stated range.
By their numbers in this assay, from the lowest: compound 2; then compound 3; then compound 4; then compound 1.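

In this assay, replacing the 1H-indol-3-yl with 4-(dimethylamino)phenyl gives a 59-fold higher number from compound 2 to compound 4 (1.77 log units; beyond the scatter), a larger loss than methyl capping of the indole nitrogen produced, and the replacement still gives a 2.7-fold higher number from compound 3 to compound 4 (0.43 log units; beyond the scatter) when the indole is already capped. Among the two phenyl compounds, dimethylamino in place of fluoro gives only a 2.5-fold lower number from compound 1 to compound 4 (0.39 log units; beyond the scatter), leaving both far from compound 2. Nothing measured here gives a cause for these steps. As far as these compounds go, whether a 4-aminophenyl or 4-hydroxyphenyl group on this aromatic carbon would behave like the 1H-indol-3-yl or like the 4-(dimethylamino)phenyl stays open.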